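Dodecylamino core: sugar versus methoxybenzyl on the ring nitrogen

The source may report more compounds than this note shows. Statements on the series, on what has been measured and on what is new or still open speak of the compounds shown alone.

Among the compounds with values here, compound 1, `CCCCCCCCCCCCNc1nc(=O)c2c(ncn2[C@H]2C[C@H](O)[C@@H](CO)O2)c(=O)[nH]1`, is the only member of the series with a numerical read-out: in an assay on isolated protein for inhibition of ATP-dependent RNA helicase SUPV3L1, mitochondrial (Homo sapiens) (on this read-out higher numbers stand for weaker inhibition and lower numbers for stronger inhibition), compound 1 gives 3 ug/mL. Compound 2, `CCCCCCCCCCCCNc1nc(=O)c2ncn([C@@H]3O[C@H](CO)[C@@H](O)[C@H]3O)c2c(=O)[nH]1`, carries a further hydroxyl on its sugar. In this assay compound 2 reaches only a limit of the assay, > 500 ug/mL, so the limit of > 500 ug/mL in this assay, at which 1 of the 2 values shown sits, describes one of the two values shown and no number is known for it. Within the data shown here, no step between measured compounds can be computed from these two values.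

Compound 3, `CCCCCCCCCCCCNc1nc(=O)c2c(ncn2Cc2ccc(OC)cc2)c(=O)[nH]1`, is the unmeasured member. It differs from compound 1 by 4-methoxybenzyl in place of 4-hydroxy-5-(hydroxymethyl)oxolan-2-yl on an aromatic nitrogen. Among the measured compounds shown here, no measured step shows what such an exchange does in this assay; the expectation therefore rests on compound 1 alone and is wide. A step toward weaker inhibition, beyond the usual scatter, is expected as a 10-fold higher number from compound 1 to compound 3 (1.00 log units; beyond the scatter). For compound 3 the estimate in this assay is 30 ug/mL, with a range from 5 ug/mL to 300 ug/mL.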

Compound 3, half-maximal inhibitory concentration: > 500 ug/mL
Compound 3: only a limit was reported; the forecaster's own chance of this, stated with the estimate: 25%; at least 16-fold (1.22 log units) between middle value and limit.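

On these data alone, the nitrogen carrying the sugar in compound 1 now has a measured exchange: in this assay, 4-methoxybenzyl in place of 4-hydroxy-5-(hydroxymethyl)oxolan-2-yl gives an at least 160-fold higher number from compound 1 to compound 3 (2.22 log units; beyond the scatter), a step set by a limit, so its true size remains unknown. The dodecylamino chain and the shared core are unchanged in this pair, so the dodecylamino chain on that core is not enough to keep the numerical read-out of compound 1, and the group on this nitrogen has a large effect on it. Numerical values remain scarce in the series, with compound 1 the only member that has one: the limit of > 500 ug/mL in this assay, at which 2 of the 3 values shown sit.

This single pair cannot separate the loss of the oxolane ring, the loss of its hydroxyl groups and the entry of the aromatic ring, and compound 2 and compound 3 cannot be ordered against each other. A plain benzyl, a 4-hydroxybenzyl or a 2-hydroxyethyl group on the same nitrogen would help to tell these contributions apart, and a shorter octylamino chain in place of the dodecylamino chain remains an open question on the core of compound 1.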